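The compounds below may be only part of what the source reports. "The series", "measured", "known", "first", "only" and "open" are said of these compounds alone.

Series notes. In a functional assay on SUP-B15 cells (Homo sapiens) for antiproliferative activity, with a stated time of 72 h (a higher number here means that more compound is needed for the effect, a lower number that less compound is needed), compound 3 `COc1ccc(-c2cc(=O)c3c(OC)cc(OC)cc3n2S(=O)(=O)c2ccc([N+](=O)[O-])cc2)cc1` gives 17100 nM, the highest of the two numbers in hand. In this assay compound 1 `COc1ccc(-c2c(Br)c(=O)c3c(OC)cc(OC)cc3n2S(=O)(=O)c2ccc(OC)cc2)cc1` gives 2920 nM, a lower number and beyond the scatter. Compound 2 `COc1ccc(-c2[nH]c3cc(OC)cc(OC)c3c(=O)c2I)cc1` reaches only a limit of this assay, > 86200 nM. That limit, (the limit of > 86200 nM in this assay, at which 1 of the 3 values shown sits), belongs to compound 2 alone. Compound 4 `COc1ccc(-c2cc(=O)c3c(OC)cc(OC)cc3n2S(=O)(=O)c2ccc(Cl)cc2)cc1` is not yet measured and differs from compound 3 by chloro in place of nitro on an aromatic carbon. Among the measured compounds shown here, no measured pair shows this exact change. For compound 4 in this assay a modest step toward a lower number is expected, possibly within the scatter, with an estimate of 8000 nM between 2500 nM and 25000 nM. This expectation means a 2.1-fold lower number from compound 3 to compound 4 (0.33 log units; beyond the scatter).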

Compound 4, half-maximal effective concentration: > 34400 nM
Compound 4: only a limit was reported (the forecaster's own chance of this, stated with the estimate: 10%); middle value at least 4.3-fold (0.63 log units) from the limit.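

The 4-nitrophenyl to 4-chlorophenyl change gives the series its first comparison in one place: in this assay the step reads an at least 2.0-fold higher number from compound 3 to compound 4 (0.30 log units; that floor lies within the scatter). Chloro in place of nitro on this aromatic carbon, para to a large group, therefore gives no lower number here, and the full size of the step stays unknown. The reading for compound 4 is a limit and not a number: the limit of > 34400 nM in this assay, at which 1 of the 4 values shown sits.

As far as these compounds go, how an amine or a carboxylic acid would read on this aromatic carbon remains open. So does whether chloro in place of nitro reads the same on a core carrying bromo.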